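From 4-chlorophenyl to phenyl at the assay limit

A few compounds are considered here, and "the series" means these few. Any claim that something is new, unique, unknown or untested is made for them only; others in the source may bear on it.

Measured in a functional assay on 786-0 cells (Homo sapiens) for inhibition, read by sulforhodamine B assay, with a stated time of 48 h; on this read-out lower numbers stand for stronger inhibition of growth and higher numbers for weaker inhibition of growth:
compound 1 `CCOC(=O)c1nn(-c2ccccc2)c(-c2ccccc2)c1CNC(C)(C)C`: 144000 nM; 42400 nM (2 entries)
compound 2 `CC(C)(C)NCc1c(C(=O)O)nn(-c2ccccc2)c1-c1ccc(F)cc1`: > 680000 nM (a limit)
compound 3 `CC(C)(C)NCc1c(C(=O)O)nn(-c2ccccc2)c1-c1ccc(Cl)cc1`: > 652000 nM (a limit)

On these results compound 3 stands at > 652000 nM and this is a limit, not a number. Compound 2 likewise stands at > 680000 nM and this too is a limit. Only compound 1 gives numbers, with the several entries of compound 1 in this assay, 144000 nM; 42400 nM (2 entries) as its record.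

The step to compound 4 `CC(C)(C)NCc1c(C(=O)O)nn(-c2ccccc2)c1-c1ccccc1` reads hydrogen in place of chloro on an aromatic carbon in full, hydrogen in place of chloro on an aromatic carbon, para to a large group. Within the data shown here, the only measured step that bears on it is a step that the two limits leave unreadable from compound 2 to compound 3 and it offers no size to carry over. No step beyond the scatter is therefore expected in this assay and compound 4 is expected to stay at the weak end with compound 3. The expected move is a step that the limit leaves unreadable from compound 3 to compound 4 and nothing larger is foreseen. Compound 4 is estimated at 700000 nM with an expected range from 250000 nM to 1000000 nM and the assay may well report only a limit again.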

Compound 4, concentration for 50% growth inhibition: > 716000 nM
Compound 4 ended at the assay's limit; the forecaster's own chance of this, stated with the estimate: 80%; at least 1.0-fold (0.00 log units) between middle value and limit.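

Among these compounds, compound 2, compound 3 and compound 4 all stand at limits rather than numbers, and no step among them can be read. The compounds shown leave open how strongly each of the three inhibits growth, and whether fluoro, chloro or hydrogen on that aromatic carbon makes any difference.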